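The source may hold more compounds than are shown below. What is called first, only, known or untested is meant among the compounds shown, and "the series" means these compounds.

Three compounds sharing one core, and differing only in the group on an amide-type nitrogen in a ring, have been read in a functional assay on HCT-116 cells (Homo sapiens) for antiproliferative activity, read by MTT assay, with a stated time of 72 h; a lower number here means a stronger inhibitor, a higher number a weaker inhibitor. Compound 1 `COc1ncc(-c2ccc3c(c2)N(C2CCCCC2)C(=O)CO3)cc1NS(=O)(=O)c1ccc(F)cc1`, with cyclohexyl there, gives > 40000 nM, which is a limit of the assay and not a number. Compound 2 `COc1ncc(-c2ccc3c(c2)N(c2ccccc2)C(=O)CO3)cc1NS(=O)(=O)c1ccc(F)cc1`, with phenyl, gives 18800 nM. Compound 3 `COc1ncc(-c2ccc3c(c2)N(C2CC2)C(=O)CO3)cc1NS(=O)(=O)c1ccc(F)cc1`, with cyclopropyl, gives 24300 nM. That places it level with the phenyl analogue, with a 1.3-fold higher number from compound 2 to compound 3 (0.11 log units; within the scatter). Leaving cyclohexyl gave an at least 2.1-fold lower number from compound 1 to compound 2 (0.32 log units; beyond the scatter) and an at least 1.6-fold lower number from compound 1 to compound 3 (0.21 log units; that floor lies within the scatter), but both of these rest on the limit.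

The next step puts 4-methoxyphenyl in place of cyclopropyl on that nitrogen to give compound 4 `COc1ccc(N2C(=O)COc3ccc(-c4cnc(OC)c(NS(=O)(=O)c5ccc(F)cc5)c4)cc32)cc1`: 4-methoxyphenyl in place of cyclopropyl on an amide-type nitrogen in a ring. Going by the values given here, the nearest precedent is compound 2, whose phenyl swap against cyclopropyl amounts to a 1.3-fold higher number from compound 2 to compound 3 (0.11 log units; within the scatter). Among the compounds with values here, no measured compound carries the methoxy group, so its contribution remains open. On that basis, the expected step in this assay is a 1.4-fold lower number from compound 3 to compound 4 (0.13 log units; within the scatter), and no change beyond the scatter is anticipated. Compound 4 is estimated at 18000 nM, with an expected range from 8000 nM to 40000 nM.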

Compound 4, half-maximal inhibitory concentration: 13400 nM
Compound 4: middle estimate off by 1.3-fold (0.13 log units), on the high side; measured number inside the range.
By their numbers in this assay, from the lowest: compounds 4, 2 and 3 (each within the scatter of the next). At a limit, above all of these: compound 1.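

In this assay, methoxy on the phenyl ring at this nitrogen gives a 1.4-fold lower number from compound 2 to compound 4 (0.15 log units; within the scatter) and the full swap of cyclopropyl for 4-methoxyphenyl gives a 1.8-fold lower number from compound 3 to compound 4 (0.26 log units; within the scatter), so neither the added oxygen nor the larger aromatic group separates compound 4 from compound 2 or compound 3, and the three remain level despite the differing sizes of these groups. Going by these compounds alone, only the comparison with cyclohexyl goes beyond the scatter, with an at least 2.9-fold lower number from compound 1 to compound 4 (0.47 log units; beyond the scatter) as the widest step seen at this position so far, and that step is a floor and not a measured distance. Going by these compounds, the value of compound 1 is a limit of the assay and not a number, so how far cyclohexyl really stands from the other three stays unknown: the limit of > 40000 nM in this assay, at which 1 of the 4 values shown sits.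

The compounds shown leave open whether any group on this nitrogen can bring the number well below this level, since all the groups here are carbon rings, with or without methoxy. An open chain such as ethyl, a ring carrying an amine, or a phenyl ring bearing a carboxylic acid would test that.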